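The source may report more compounds than this note shows. Statements on the series, on what has been measured and on what is new or still open speak of the compounds shown alone.

Measured so far in a functional assay on isolated protein for inhibition of Glucose-dependent insulinotropic receptor (Homo sapiens), read by HTRF and cAMP accumulation; on this read-out lower numbers stand for an effect already at smaller amounts and higher numbers for an effect only at larger amounts of compound:
- compound 1 `Cc1nc(S(C)(=O)=O)ccc1Oc1ncnc(OC2CCN(C(=O)SC(C)(C)C)CC2)c1F`: 4.83 nM
- compound 2 `Cc1nc(S(C)(=O)=O)ccc1Oc1ncnc(OC2CCN(C(=O)C3(C)CC3)CC2)c1F`: 761 nM

Compound 2 holds the highest of the two numbers in this assay; its nearest neighbour is compound 1, and the step of a 160-fold higher number from compound 1 to compound 2 (2.20 log units; beyond the scatter) separates them, well beyond the scatter.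

Compound 3 `CCc1cnc(C(=O)N2CCC(Oc3ncnc(Oc4ccc(S(C)(=O)=O)nc4C)c3F)CC2)nc1` differs from compound 2 in one place: 5-ethylpyrimidin-2-yl in place of 1-methylcyclopropyl on a carbonyl carbon. Going by the values given here, no measured pair shows this exchange directly. Among the compounds with values here, the only step that bears on it is a 160-fold higher number from compound 1 to compound 2 (2.20 log units; beyond the scatter), which concerns the same carbonyl carbon and shows that the group attached there moves the number by a large amount. That step gives the size the position can deliver, not the direction for an aromatic group with two acceptors entering there.

Given that width, a step of some size is expected rather than none, and the working expectation is a lower number for compound 3, estimated as a 13-fold lower number from compound 2 to compound 3 (1.10 log units; beyond the scatter), with the uncertainty kept wide. Compound 3 is therefore estimated at 60 nM in this assay, within a range of 5 nM to 700 nM.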

Compound 3, half-maximal effective concentration: 4.7 nM
Estimate against measurement, compound 3: 13-fold (1.11 log units) above; the whole stated range lies above it.
By their numbers in this assay, from the lowest: compounds 3 and 1 (each within the scatter of the next); then compound 2.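

In this assay, the carbonyl carbon on the amide-type nitrogen in a ring now shows a large step in the opposite direction: 5-ethylpyrimidin-2-yl in place of 1-methylcyclopropyl gives a 160-fold lower number from compound 2 to compound 3 (2.21 log units; beyond the scatter), so a low number at this position is not tied to the (tert-butyl)sulfanyl group of compound 1. With 5-ethylpyrimidin-2-yl in place of (tert-butyl)sulfanyl the series gives a 1.0-fold lower number from compound 1 to compound 3 (0.01 log units; within the scatter), so two very different groups read alike here and, of the three groups shown, only 1-methylcyclopropyl stands apart. Nothing at hand gives a cause for either step.

On these data alone, it remains open whether the ring nitrogens or the ethyl chain carry the change, which a phenyl ring with the same ethyl chain, or a pyrimidin-2-yl without it, would separate. Also open, as far as these compounds go, is whether a plain tert-butyl or a tert-butoxy on the same carbonyl carbon would read like 1-methylcyclopropyl or like (tert-butyl)sulfanyl.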